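The source may hold more compounds than are shown below. What is called first, only, known or untested is meant among the compounds shown, and "the series" means these compounds.

Measured compounds: compound 1 `C=Cc1ccc(S(=O)(=O)Nc2ccc3oc(-c4ccccc4)nc3c2)cc1`, > 100000 nM; compound 2 `COc1cccc(S(=O)(=O)Nc2ccc(-c3nc4ccccc4o3)cc2)c1`, 80000 nM.

Compound 1 and compound 2 were both examined in an assay on cells for inhibition of HSP60/HSP10 (Homo sapiens), with a stated time of 60 min; on this read-out higher numbers stand for weaker inhibition and lower numbers for stronger inhibition. For compound 1 the result is a limit of the assay, > 100000 nM, not a number, the point described as the limit of > 100000 nM in this assay, at which 1 of the 2 values shown sits. Compound 2 gives 80000 nM in this assay, a value within the measurable range. Going by the values given here, no step between these two compounds is computed here, so their values show only that both sit at the weak end of what this assay can report.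

Compound 3 `CS(=O)(=O)Nc1ccc2oc(-c3ccccc3)nc2c1` has not yet been tested. It differs from compound 1 by methyl in place of 4-vinylphenyl on a sulfonyl sulfur. Among the compounds with values here, because compound 1 already sits at the limit of > 100000 nM in this assay, at which 1 of the 2 values shown sits, there is no measured step from which the direction of this change can be read; the step from compound 1 to compound 3 is expected to be a step that the limit leaves unreadable from compound 1 to compound 3, within the scatter or toward weaker inhibition. Compound 3 is therefore estimated at 150000 nM, with a range from 50000 nM to 500000 nM, and the assay will most likely again report only a limit.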

Compound 3, half-maximal inhibitory concentration: > 100000 nM
Compound 3: no number, only a limit (the forecaster's own chance of this, stated with the estimate: 70%); the middle value lies beyond the limit too.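

Compound 3, like compound 1, gives only a limit in this assay and no number, so no step can be read between compound 1 and compound 3: the limit of > 100000 nM in this assay, at which 2 of the 3 values shown sit.

The compounds shown leave open whether methyl in place of 4-vinylphenyl on a sulfonyl sulfur changes inhibition at all.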